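The source may hold more compounds than are shown below. What is called first, only, known or untested is meant among the compounds shown, and "the series" means these compounds.

Compound 1 `NS(=O)(=O)c1ccc(Nc2ncc(F)c(Nc3nc4ccc(Cl)cc4s3)n2)cc1` and compound 2 `Cc1cnc(Nc2ccc(S(N)(=O)=O)cc2)nc1Nc1nc2ccc(Cl)cc2s1` share one core, and compound 3 `NS(=O)(=O)c1ccc(Nc2nccc(Nc3nc4ccc(F)cc4s3)n2)cc1` carries a different one; the difference between the two cores is not broken down here. In a functional assay on PC-3 cells (Homo sapiens) for antiproliferative activity, read by MTT assay, with a stated time of 48 h (on this read-out higher numbers stand for weaker inhibition and lower numbers for stronger inhibition), compound 1 gives 1430 nM and compound 2 gives 5400 nM, so the change methyl in place of fluoro on an aromatic carbon made a step of a 3.8-fold higher number from compound 1 to compound 2 (0.58 log units; beyond the scatter). In this assay compound 3 gives 920 nM. Compound 4 `Cc1ccc2nc(Nc3ccnc(Nc4ccc(S(N)(=O)=O)cc4)n3)sc2c1` has not yet been measured; it differs from compound 3 by methyl in place of fluoro on an aromatic carbon. This is the same kind of change, but not the same: the earlier one sits on a six-membered aromatic ring with two nitrogen, ortho and para to a large group, whereas this one sits on a ring of carbon only within a fused system, meta and para to a fused ring. Because the earlier step was a 3.8-fold higher number from compound 1 to compound 2 (0.58 log units; beyond the scatter), a smaller weakening of a 1.6-fold higher number from compound 3 to compound 4 (0.21 log units; within the scatter) is expected in this assay, with compound 4 estimated at 1500 nM.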

Compound 4, half-maximal inhibitory concentration: 1640 nM
Compound 4: the middle estimate sits 1.1-fold (0.04 log units) below what was measured; the measured number falls inside the stated range.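

In this assay, methyl in place of fluoro on the ring of carbon only gives a 1.8-fold higher number from compound 3 to compound 4 (0.25 log units; within the scatter). Set beside the earlier step, the two results do not separate, so the change reads alike on both cores as far as this assay can tell: the same change on two cores in this assay, a 3.8-fold higher number (0.58 log units; beyond the scatter) from compound 1 to compound 2 and a 1.8-fold higher number (0.25 log units; within the scatter) from compound 3 to compound 4, 2.1-fold (0.33 log units) apart, within the scatter of two such steps. Going by these compounds alone, this rests on only two pairs, with the change at a different place in each and only the earlier step beyond the scatter, so it does not show a fixed step size that would carry to further cores.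

As far as these compounds go, whether an amine or a methoxy group at these same places would give a similar step remains open. So does whether a trifluoromethyl group would.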